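Chalcone series: removal of the enone-bromopyridyl arm

The compounds below may be only part of what the source reports. "The series", "measured", "known", "first", "only" and "open" are said of these compounds alone.

Compound 3 `Cc1cc(Nc2ccc(C(=O)/C=C/c3cccc(Br)n3)cc2)n2nc(SCc3nc4ccccc4[nH]3)nc2n1` is one of three close analogues sharing a core, differing only at the saturated chain carbon bound to a sulfur. In a functional assay on MGC-803 cells (Homo sapiens) for inhibition, read by sulforhodamine B assay, with a stated time of 72 h, tested at 10 uM (on this read-out higher numbers stand for more inhibition at the one concentration tested (going by the name of the read-out) and lower numbers for less inhibition), compound 3 gives 94.4%. Among the compounds with values here, compound 2 `C#CCSc1nc2nc(C)cc(Nc3ccc(C(=O)/C=C/c4cccc(Br)n4)cc3)n2n1` gives 94.4% and compound 1 `Cc1cc(Nc2ccc(C(=O)/C=C/c3cccc(Br)n3)cc2)n2nc(SCc3ccc(F)cc3)nc2n1` gives 93.3%; the three values are within the scatter of one another, as the steps of a number 1.1 percentage points higher from compound 1 to compound 2 (within the scatter), a number 1.1 percentage points higher from compound 1 to compound 3 (within the scatter) and no change at the digits printed from compound 2 to compound 3 (within the scatter) show, so compound 3 is level with compound 2 and no compound stands apart.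

Compound 4 `Cc1cc(Nc2ccccc2)n2nc(SCc3nc4ccccc4[nH]3)nc2n1` has not been measured. It differs from compound 3 in a single place: hydrogen in place of (2-(6-bromopyridin-2-yl)ethenyl)carbonyl on an aromatic carbon

None of the three measured steps touches this part of the molecule; all of them vary the group on the sulfur-bound carbon while the (2-(6-bromopyridin-2-yl)ethenyl)carbonyl is kept. The step of a number 54.4 percentage points lower from compound 3 to compound 4 (beyond the scatter) is therefore only what is expected, an estimate with no precedent behind it, and its size cannot be anchored to any shown number. Within the data shown here, with the larger group gone and no comparable step available, the estimate for compound 4 in this assay is 40%, expected to fall between 5% and 85%, a wide range reflecting the absence of any bearing data.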

Compound 4, a percentage reported as inhibition, at one concentration (the size of the read-out at that concentration, not a potency): 22.4%
For compound 4 the middle estimate is 17.6 percentage points above the measured one; measured number inside the range.
By their numbers in this assay, from the lowest: compound 4; then compounds 1, 2 and 3 (each within the scatter of the next).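

In this assay, the sulfur-bound carbon and the aromatic carbon bearing the (2-(6-bromopyridin-2-yl)ethenyl)carbonyl respond very differently: replacing that group with hydrogen gives a number 72 percentage points lower from compound 3 to compound 4 (beyond the scatter), whereas the changes among compound 1, compound 2 and compound 3 all stay within the scatter. The single-place comparison therefore marks this aromatic position as the far more sensitive of the two sites varied, although it rests on one pair carrying 1H-benzimidazol-2-yl on the sulfur-bound carbon. Nothing available bears on why removing the group has so large an effect.

The compounds shown do not divide the step among the carbonyl, the ethenyl link and the bromopyridine ring; a plain acetyl group or an unsubstituted cinnamoyl group at this place would separate these parts. From the compounds shown here alone, whether the same loss occurs with 4-fluorophenyl or ethynyl on the sulfur-bound carbon remains open.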